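A few compounds are considered here, and "the series" means these few. Any claim that something is new, unique, unknown or untested is made for them only; others in the source may bear on it.

The set contains three measured compounds and one awaiting its number. Compound 1 `CC(C)c1onc(-c2c(Cl)cccc2Cl)c1COc1ccc(-c2nc3cc(C(=O)O)ccc3n2C)cc1` gives 25.8 nM in an assay on Huh-7 cells for agonist activity at Bile acid receptor (Homo sapiens), read by a luciferase reporter (a lower number here means that less compound is needed, a higher number that more compound is needed for the effect), compound 2 `CC(C)c1onc(-c2c(Cl)cccc2Cl)c1COc1ccc(-c2nc3ccc(C(=O)O)cc3n2CC2CCCCC2)c(F)c1` gives 7.8 nM, and compound 3 `CCn1c(-c2ccc(OCc3c(-c4c(Cl)cccc4Cl)noc3C(C)C)cc2)nc2ccc(C(=O)O)cc21` gives 2.31 nM. Compound 3 therefore stands lowest of the three, and both gaps to it, from compound 2 and from compound 1, lie beyond the scatter of repeated measurements. Compound 4 `CC(C)Cn1c(-c2ccc(OCc3c(-c4c(Cl)cccc4Cl)noc3C(C)C)cc2)nc2ccc(C(=O)O)cc21` is the next step. It differs from compound 3 in one place: isopropyl in place of methyl on a saturated chain carbon bound to an aromatic nitrogen, a change that, cut one bond further out, reads ethyl to isobutyl. Within the data shown here, no step between two measured compounds isolates this change, so only the surrounding numbers can guide an expectation. Compound 1 and compound 2 carry a methyl and a cyclohexylmethyl on the aromatic nitrogen, and compound 2 comes out lower, but those two also differ elsewhere. Compound 4 is expected to move little, with a step of a 1.3-fold higher number from compound 3 to compound 4 (0.11 log units; within the scatter) not beyond the scatter. The estimated value of compound 4 is 3 nM, within a range of 1 nM to 9 nM.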

Compound 4, half-maximal effective concentration: 5.26 nM
Compound 4: the middle estimate sits 1.8-fold (0.24 log units) below what was measured, and the stated range covers the measured number.
By their numbers in this assay, from the lowest: compound 3; then compounds 4 and 2 (each within the scatter of the next); then compound 1.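

Among these compounds, this is the first step in the set that isolates the group on the aromatic nitrogen: with everything else unchanged, isopropyl in place of methyl on a saturated chain carbon bound to an aromatic nitrogen gives a 2.3-fold higher number from compound 3 to compound 4 (0.36 log units; beyond the scatter) in this assay. The position therefore responds to the change from ethyl to isobutyl, although the step is modest and the larger group is tolerated at a modest cost in this read-out. Nothing measured for these compounds accounts for the step.

A single step cannot show whether the rise follows the added carbon count or the branching of the isobutyl chain. From the compounds shown here alone, it also remains open how an unbranched propyl chain, or a chain ending in a hydroxyl group, would compare with ethyl and isobutyl at this place.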